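A few compounds are considered here, and "the series" means these few. Any claim that something is new, unique, unknown or untested is made for them only; others in the source may bear on it.

Measured so far:
compound 1, `Oc1ccccc1SCc1ccccc1`: > 3.78
compound 2, `O=C1C=C(O)CC1Cc1ccccc1`: -0.7

In a physicochemical assay for lipophilicity, read by LC-MS, using the shake flask method, with a stated time of 1 h, at pH 7.4 (on this read-out lower numbers stand for lower lipophilicity and higher numbers for higher lipophilicity), compound 1 gives > 3.78, which is a limit of the assay rather than a number. (the limit of > 3.78 in this assay, at which 1 of the 2 values shown sits). Going by the values given here, compound 2 gives -0.7 in this assay; this is the only plain number in the set, so compound 2 cannot be placed in order against anything measured.

Compound 3, `CC1=C(O)CC(Cc2ccccc2)C1=O`, is not yet measured. It differs from compound 2 by methyl in place of hydrogen on a double-bonded ring carbon. Among the compounds with values here, no step between measured compounds covers this change, so its size rests on expectation alone. The step expected is a number 0.50 log units higher from compound 2 to compound 3 (beyond the scatter), a small rise in this assay, close to the edge of the usual scatter. Compound 3 is therefore estimated at -0.2, with a range from -0.7 to 0.3.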

Compound 3, distribution coefficient: -0.33
Compound 3: middle estimate off by 0.13 log units, on the high side; measured number inside the range.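

In this assay, methyl in place of hydrogen on a double-bonded ring carbon gives a number 0.37 log units higher from compound 2 to compound 3 (beyond the scatter). Going by these compounds alone, this is the first measured step with a plain number at both ends, and it ties a size to one place: on the double-bonded ring carbon next to the ring atom that bears a hydroxy group. Within the data shown here, nothing measured so far gives a cause for this step.

A single step leaves open whether a longer chain such as ethyl, a fluorine or an amine on the same carbon would shift the read-out in the same direction or by a similar size. Among these compounds, compound 1 gives > 3.78, which is a limit of the assay and not a number, so it provides no step for this series.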